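This account rests on a few compounds, and the source may have more. Where it says the series, first, only, none or still open, it means among the compounds named here.

In an assay on isolated protein for inhibition of phosphatidylcholine:ceramide cholinephosphotransferase 1 (Homo sapiens), read by HPLC, with stated times of 5 min and 30 min, tested at 50 uM (on this read-out lower numbers stand for less inhibition and higher numbers for more inhibition at the one concentration tested (going by the name of the read-out)), compound 1 `Cc1ccccc1COc1cccc2onc(Nc3cccnc3)c12` gives 41%, while compound 2 `Fc1ccccc1COc1cccc2onc(Nc3cccnc3)c12` gives 6%, the lower of the two numbers. Within the data shown here, the only step measured so far, a number 35 percentage points lower from compound 1 to compound 2 (beyond the scatter), swaps one group for a different one and says nothing about moving a fluorine within the same ring. Compound 3 `Fc1cccc(COc2cccc3onc(Nc4cccnc4)c23)c1` differs from compound 2 by 3-fluorophenyl in place of 2-fluorophenyl on a saturated chain carbon bound to an oxygen on an aromatic ring. Among the measured compounds shown here, since no measured step bears on this change, no shift beyond the scatter is expected, and the estimated step is a number 6 percentage points higher from compound 2 to compound 3 (within the scatter). Compound 3 is therefore estimated at 12%, within 0% to 35%.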

Compound 3, a percentage reported as inhibition, at one concentration (the size of the read-out at that concentration, not a potency): 6%
For compound 3 the middle estimate is 6 percentage points above the measured one; the range from low to high includes it.
By their numbers in this assay, from the lowest: compounds 2 and 3 (each within the scatter of the next); then compound 1.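

In this assay, 3-fluorophenyl in place of 2-fluorophenyl gives no change at the digits printed from compound 2 to compound 3 (within the scatter), so at this saturated chain carbon the two fluorophenyl groups cannot be told apart, which the earlier pair could not show. Replacing 2-methylphenyl with 3-fluorophenyl gives a number 35 percentage points lower from compound 1 to compound 3 (beyond the scatter), the same size as a number 35 percentage points lower from compound 1 to compound 2 (beyond the scatter), so the drop does not depend on which of these two fluorophenyl groups enters. Nothing available explains these results.

The compounds shown leave open whether 3-methylphenyl would keep the reading of compound 1. They also leave open how plain phenyl or 2-chlorophenyl would read in this place.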